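Phenoxy for benzylamino on the shared core

The compounds below may be only part of what the source reports. "The series", "measured", "known", "first", "only" and "open" are said of these compounds alone.

Among the measured compounds shown here, compound 1 `Nc1cc(N)c2nc(-c3ccccc3)c(NCc3ccc(F)cc3)nc2c1` is the one member of the series with a read number: in a functional assay on SNB-19 cells (Homo sapiens) for inhibition, read by sulforhodamine B assay, with a stated time of 48 h (a lower number here means that less compound is tolerated, a higher number that more compound is tolerated), compound 1 gives 52500 nM. Compound 2 `COc1ccc(CNc2nc3cc(N)cc(N)c3nc2-c2ccccc2)cc1` reaches only a limit of this assay, < 100000 nM, so the step that the limit leaves unreadable from compound 1 to compound 2 cannot be sized; the limit of < 100000 nM in this assay, at which 1 of the 2 values shown sits, marks where that limit sits. Compound 3 `Nc1cc(N)c2nc(-c3ccccc3)c(Oc3ccc(F)cc3)nc2c1` carries 4-fluorophenoxy in place of (4-fluorobenzyl)amino on an aromatic carbon. For the measured compounds named here, no measured step covers an exchange of this kind; the one step on record concerns a substituent on the pendant ring and is itself unreadable. The expectation for compound 3 therefore rests on compound 1 alone, with no direction assignable, so a 1.1-fold lower number from compound 1 to compound 3 (0.02 log units; within the scatter) is expected to stay within the scatter, with a broad spread to either side. Compound 3 is estimated at 50000 nM in this assay, between 15000 nM and 100000 nM.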

Compound 3, concentration lethal to 50% of the cells: 66100 nM
Estimate against measurement, compound 3: 1.3-fold (0.12 log units) below; low and high end bracket the measured number.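

In this assay, among the compounds shown here, 4-fluorophenoxy in place of (4-fluorobenzyl)amino on this aromatic carbon gives a 1.3-fold higher number from compound 1 to compound 3 (0.10 log units; within the scatter), the first readable step. The position thus accepts the change from a linker with a hydrogen-bond donor to an oxygen-linked aryl group with none, and the read-out stays within the scatter. This step concerns the link to the fluorinated ring itself, whereas the earlier comparison concerned only a substituent on that ring and gave no size.

From the compounds shown here alone, compound 2 remains a limit and not a number, so its step cannot be read: the limit of < 100000 nM in this assay, at which 1 of the 3 values shown sits. Still open is whether an amine, a carboxylic acid or a longer chain in place of 4-fluorophenoxy at this position would give a step beyond the scatter.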